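A few compounds are considered here, and "the series" means these few. Any claim that something is new, unique, unknown or untested is made for them only; others in the source may bear on it.

Measured so far:
compound 1 `CCc1cccn1C1=CC(C)(C)Oc2ccc(C#N)cc21` — > 20000 nM
compound 2 `CC1(C)C=C(n2ccc(C#N)c2)c2cc(C#N)ccc2O1` — 2400 nM

In a functional assay (Trachealis) for inhibition, with Cavia porcellus as the target (on this read-out lower numbers stand for stronger inhibition and higher numbers for weaker inhibition), compound 1 gives only a limit, > 20000 nM. In this assay compound 2 gives 2400 nM. Within the data shown here, the one measured step, an at least 8.3-fold lower number from compound 1 to compound 2 (0.92 log units; beyond the scatter), swaps 3-cyano-1H-pyrrol-1-yl for 2-ethyl-1H-pyrrol-1-yl on a double-bonded ring carbon of the shared core.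

Compound 3 `CC(=O)c1cccn1C1=CC(C)(C)Oc2ccc(C#N)cc21` keeps the core of compound 1 and changes it as follows: acetyl in place of ethyl on an aromatic carbon. The ethyl leaves and an acetyl enters on an aromatic carbon of a five-membered aromatic ring with 1 nitrogen. The step from compound 1 to compound 2 is the only one that bears on this, and it is indirect: it changes the same ring, but at another position and with another group, and starts from a limit (the limit of > 20000 nM in this assay, at which 1 of the 2 values shown sits). A modest gain is expected, with wide uncertainty. Compound 3 is estimated at 7000 nM, between 1500 nM and 30000 nM, which would mean an expected step of an at least 2.8-fold lower number from compound 1 to compound 3 (0.45 log units; beyond the scatter) in this assay.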

Compound 3, half-maximal inhibitory concentration: > 20000 nM
Compound 3 gave a limit, no number (the forecaster's own chance of this, stated with the estimate: 35%); middle value at least 2.8-fold (0.45 log units) from the limit.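

Compound 1 and compound 3 both give only a limit in this assay, so no step between them can be read: the limit of > 20000 nM in this assay, at which 2 of the 3 values shown sit.

The compounds shown leave open whether acetyl in place of ethyl on an aromatic carbon changes inhibition at all, and by how much.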